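This account rests on a few compounds, and the source may have more. Where it says the series, first, only, none or still open, it means among the compounds named here.

Going by the values given here, in a functional assay on Flp-In T-REx293 cells for antagonist activity at Free fatty acid receptor 1 (Homo sapiens), read by calcium flux (on this read-out lower numbers stand for stronger inhibition and higher numbers for weaker inhibition), compound 1 `O=S1(=O)c2ccccc2CN1c1cc(F)cc(OCc2ccccc2)c1` gives 2450 nM, and compound 2 `Cc1cccc(Oc2cc(F)cc(N3Cc4ccccc4S3(=O)=O)c2)c1` gives 25100 nM, the highest of the two numbers measured so far; its nearest neighbour is compound 1, reached by a 10-fold higher number from compound 1 to compound 2 (1.01 log units; beyond the scatter). Compound 3 `Cc1ccc(Oc2cc(F)cc(N3Cc4ccccc4S3(=O)=O)c2)cc1` differs from compound 2 by 4-methylphenyl in place of 3-methylphenyl on an oxygen on an aromatic ring. Among the compounds with values here, no measured step bears directly on this change: the only step known swapped the whole group on the oxygen rather than moving the methyl on the same ring. With nothing to go on, the expected step is a 1.0-fold lower number from compound 2 to compound 3 (0.00 log units; within the scatter), none beyond the scatter. Compound 3 is therefore estimated at 25000 nM, ranging from 8000 nM to 80000 nM.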

Compound 3, half-maximal inhibitory concentration: 2880 nM
Compound 3: the middle estimate sits 8.7-fold (0.94 log units) above what was measured; measured number below the stated range.
By their numbers in this assay, from the lowest: compounds 1 and 3 (each within the scatter of the next); then compound 2.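

Moving a single methyl, with the same atoms in both groups, gives an 8.7-fold lower number from compound 2 to compound 3 (0.94 log units; beyond the scatter), so the group on this oxygen is sensitive to where that methyl sits. The high number of compound 2 therefore does not extend to every methylphenyl group: replacing benzyl with 4-methylphenyl gives a 1.2-fold higher number from compound 1 to compound 3 (0.07 log units; within the scatter). Nothing available explains why the methyl's place matters. Still open, on these data alone, is whether the methyl is needed at all, or whether plain phenyl, 4-chlorophenyl or 4-methoxyphenyl on the same oxygen would give a similar number.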